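Series notes: the step from compound 2 to compound 4

This account rests on a few compounds, and the source may have more. Where it says the series, first, only, none or still open, it means among the compounds named here.

Measured so far:
compound 1 `CC(=O)Nc1nc(-c2cccc(NS(=O)(=O)c3cccc(Br)c3)c2)cs1` gives 67.4% in this assay.
compound 2 `CC(=O)Nc1nc(-c2cccc(NS(=O)(=O)c3ccc(C#C[Si](C)(C)C)cc3)c2)cs1` gives 4.2%.
compound 3 `CC(=O)Nc1nc(-c2cccc(NS(=O)(=O)c3cccc(C#C[Si](C)(C)C)c3)c2)cs1` gives < 1%, which is a limit of the assay and not a number.

In a functional assay on A-375 cells (Homo sapiens) for antiproliferative activity, read by trypan blue exclusion, with a stated time of 48 h, tested at 5 uM (on this read-out lower numbers stand for a stronger effect and higher numbers for a weaker effect at the one concentration tested), compound 2 stands lowest of the two numbers that are numbers; the nearest is compound 1, whose value lies far higher, beyond the scatter. The value of compound 3 sits at the limit of < 1% in this assay, at which 1 of the 3 values shown sits. For the measured compounds named here, the only step between compounds that differ in one place is a number at least 66.4 percentage points lower from compound 1 to compound 3 (beyond the scatter), a large drop.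

Compound 4 `CCCCCCCCc1ccc(S(=O)(=O)Nc2cccc(-c3csc(NC(C)=O)n3)c2)cc1` is not yet measured. It differs from compound 2 by a group of 8 heavy atoms (8 carbon; no ring) in place of a group of 6 heavy atoms (5 carbon, 1 silicon; no ring), on an aromatic carbon. Going by the values given here, no measured step replaces the six-atom group with an octyl, so the step from compound 1 to compound 3 bears on this change only indirectly: it shows that exchanging the group on that aromatic carbon can move the read-out a long way. Compound 2 already sits close to the lower limit, leaving little room for a further fall, so the expected step is a number 7.8 percentage points higher from compound 2 to compound 4 (within the scatter), a modest rise or none beyond the scatter. Compound 4 is therefore estimated at 12%, in the range 1% to 35%.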

Compound 4, a percentage reported as activity, at one concentration (the size of the read-out at that concentration, not a potency): < 1%
Compound 4 ended at the assay's limit; the forecaster's own chance of this, stated with the estimate: 15%; at least 11 percentage points between middle value and limit.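

In this assay compound 4 gives < 1%, which is a limit of the assay and not a number, and the read-out now stops there for a second compound of the series: the limit of < 1% in this assay, at which 2 of the 4 values shown sit.

The change at this position reads as a number at least 3.2 percentage points lower from compound 2 to compound 4 (that floor lies within the scatter), so the entry of octyl brings no sign of a loss, though the size of any gain cannot be read. On an aromatic carbon para to a large group, neither the triple bond nor the silicon of the leaving group is therefore needed for a read-out this low, since a chain of carbon alone holds it there.

With one concentration and a read-out at its limit, the compounds shown leave open whether compound 4 and compound 2 differ at all in potency, which would take lower concentrations or a full concentration series to settle. Also open, on these data alone, is how far the effect at this position depends on the chain itself: a shorter chain such as butyl, or an octyl chain ending in an amine or a carboxylic acid, would test this directly.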